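Isopropyl for Cyclopropyl on a Sulfonamide Nitrogen

The source may hold more compounds than are shown below. What is called first, only, known or untested is meant among the compounds shown, and "the series" means these compounds.

Compound 1 `CC(C)c1noc(N2CCN(C(=O)[C@@H]3CCCN(S(=O)(=O)c4ccc(S(=O)(=O)NC5CC5)cc4)C3)CC2)n1` has been tested in a functional assay on MIA PaCa-2 cells (Homo sapiens) for inhibition, read by MTT assay, with a stated time of 3 days; a higher number here means a weaker inhibitor, a lower number a stronger inhibitor. In this assay compound 1 gives > 10000 nM, which is a limit of the assay and not a number. A second compound, compound 2 `CCOC(=O)[C@@H]1CCCN(S(=O)(=O)c2ccc(S(=O)(=O)N(CC)CC)cc2C)C1`, has been run in the same way. In this assay compound 2 gives > 10000 nM, again a limit and not a number. Everything measured so far is thus (the limit of > 10000 nM in this assay, at which 2 of the 2 values shown sit), and no step between two measured compounds exists to show how a single change moves the read-out.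

Compound 3 `CC(C)NS(=O)(=O)c1ccc(S(=O)(=O)N2CCC[C@@H](C(=O)N3CCN(c4nc(C(C)C)no4)CC3)C2)cc1` remains to be measured. Its difference from compound 1 is isopropyl in place of cyclopropyl on a sulfonamide nitrogen. With both known values at the limit, the data give no direction for this change. The expected step in this assay is a step that the limit leaves unreadable from compound 1 to compound 3, none beyond the scatter, and a further limit is the likeliest outcome. Compound 3 is estimated at 15000 nM, within 5000 nM to 60000 nM.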

Compound 3, half-maximal inhibitory concentration: > 10000 nM
Compound 3 ended at the assay's limit; the forecaster's own chance of this, stated with the estimate: 85%; the middle value lies beyond the limit too.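

In this assay compound 3 gives > 10000 nM as a limit and not a number. Among the compounds shown here, no step from compound 1 to compound 3 can be read, since both sit at the limit: the limit of > 10000 nM in this assay, at which 3 of the 3 values shown sit. The compounds shown leave open whether swapping cyclopropyl for isopropyl has any effect on inhibition, and in which direction.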